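Swapping a Difluorophenyl Amide for a Cyclohexyl Amide

The source may report more compounds than this note shows. Statements on the series, on what has been measured and on what is new or still open speak of the compounds shown alone.

Three compounds have been measured in an ADME assay on TZM cells (Homo sapiens) for cytotoxicity, read by CCK-8 assay, with a stated time of 2 days; a higher number here means that more compound is tolerated, a lower number that less compound is tolerated:

Compound 1, `CC(=O)Oc1ccc(/C=C/S(=O)(=O)CCc2ccc(NC(=O)c3cc(F)cc(F)c3)cc2)cc1OC(C)=O`, gives 225000 nM.
Compound 2, `CC(=O)Oc1ccc(/C=C/S(=O)(=O)CCc2ccc(NC(=O)C3CCCCC3)cc2)cc1OC(C)=O`, gives 169000 nM.
Compound 3, `O=C(Nc1ccc(CCS(=O)(=O)/C=C/c2ccc(O)c(O)c2)cc1)c1cc(F)cc(F)c1`, gives 414000 nM.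

Compound 1 and compound 2 differ in one place only, (cyclohexyl in place of 3,5-difluorophenyl on a carbonyl carbon), and that change gave a 1.3-fold lower number from compound 1 to compound 2 (0.12 log units; within the scatter). Compound 3 carries the same difluorophenyl amide as compound 1 but on a different core; how the two cores differ is not broken down here, and the two values show compound 3 a little higher than compound 1, within the scatter.

Compound 4, `O=C(Nc1ccc(CCS(=O)(=O)/C=C/c2ccc(O)c(O)c2)cc1)C1CCCCC1`, has not yet been measured in this assay. It arises from compound 3 by cyclohexyl in place of 3,5-difluorophenyl on a carbonyl carbon. The place of this change is worded exactly as for the change from compound 1 to compound 2, so it is the same change on the other core. Because that change gave a 1.3-fold lower number from compound 1 to compound 2 (0.12 log units; within the scatter), the step from compound 3 to compound 4 is expected to be about as small, a 1.3-fold lower number from compound 3 to compound 4 (0.11 log units; within the scatter). Compound 4 is therefore estimated at 320000 nM, expected to lie between 150000 nM and 650000 nM.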

Compound 4, half-maximal cytotoxic concentration: 638000 nM
Beside the measured number, compound 4's estimate is 2.0-fold (0.30 log units) below it, and the stated range covers the measured number.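

In this assay, putting cyclohexyl in place of 3,5-difluorophenyl on the carbonyl carbon gave a 1.5-fold higher number from compound 3 to compound 4 (0.19 log units; within the scatter), so on this core too the swap stays inside the usual scatter. On paper the two steps point in opposite directions, but that gap is no real difference: the same change on two cores in this assay, a 1.3-fold lower number (0.12 log units; within the scatter) from compound 1 to compound 2 and a 1.5-fold higher number (0.19 log units; within the scatter) from compound 3 to compound 4, 2.1-fold (0.31 log units) apart, within the scatter of two such steps. The change therefore carries from one core to the other as a swap with no readable effect on how much compound the cells tolerate, but this does not show that its effect is truly zero or that any small effect shares the same direction on both cores, and two cores cannot speak for the whole series.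

The compounds shown place only these two groups on that carbonyl carbon, so it stays open what a straight hexyl chain, or a cyclohexyl ring carrying an amine or a carboxylic acid, would do to the number. They also leave open whether the swap would stay this small on a third core.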